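A few compounds are considered here, and "the series" means these few. Any claim that something is new, unique, unknown or untested is made for them only; others in the source may bear on it.

Compound 1, `N[C@H]1CC[C@@H](Oc2ccc([C@H]3CC[C@]4(CC3)OOC3(O4)C4CC5CC(C4)CC3C5)cc2)CC1`, was tested in an ADME assay on microsomes from liver (Homo sapiens) for metabolic stability, read by LC-MS, tested at 1 uM; a higher number here means faster removal of the compound, a lower number slower removal. In this assay compound 1 gives < 7 mL.min-1.g-1, which is a limit of the assay rather than a number. Two close relatives have been measured in the same way. Compound 2, `NCCCOc1ccc([C@H]2CC[C@]3(CC2)OOC2(O3)C3CC4CC(C3)CC2C4)cc1`, gives < 7 mL.min-1.g-1 in this assay, again a limit. Compound 3, `CC(C)(CN)Oc1ccc([C@H]2CC[C@]3(CC2)OOC2(O3)C3CC4CC(C3)CC2C4)cc1`, gives < 7 mL.min-1.g-1 in this assay, also a limit. The steps between them, a step that the two limits leave unreadable from compound 1 to compound 2, a step that the two limits leave unreadable from compound 1 to compound 3 and a step that the two limits leave unreadable from compound 2 to compound 3, cannot be sized because all three values sit at the same limit (the limit of < 7 mL.min-1.g-1 in this assay, at which 3 of the 3 values shown sit). The not yet measured compound 4, `NC(=O)C1CCN(Cc2ccc([C@H]3CC[C@]4(CC3)OOC3(O4)C4CC5CC(C4)CC3C5)cc2)CC1`, differs from compound 1 in one place: (4-carbamoylpiperidin-1-yl)methyl in place of (4-aminocyclohexyl)oxy on an aromatic carbon. Within the data shown here, no measured step covers this particular change. Among the measured compounds shown here, all three measured compounds sit at the limit, and that is the only guide available. On that basis compound 4 is expected to give 5 mL.min-1.g-1 in this assay, with a range of 2 mL.min-1.g-1 to 12 mL.min-1.g-1. The estimated step that the limit leaves unreadable from compound 1 to compound 4 is expected to stay within the usual scatter.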

Compound 4, intrinsic clearance in microsomes: 10 mL.min-1.g-1
Compound 4: middle estimate off by 2.0-fold (0.30 log units), on the low side; measured number inside the range.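

In this assay compound 4 is the only compound shown with a number rather than a limit, at 10 mL.min-1.g-1, so this change on an aromatic carbon, para to a large group, is the first that can be given even a minimum size. Putting (4-carbamoylpiperidin-1-yl)methyl at this place gives an at least 1.4-fold higher number from compound 1 to compound 4 (0.15 log units; that floor lies within the scatter), an at least 1.4-fold higher number from compound 2 to compound 4 (0.15 log units; that floor lies within the scatter) and an at least 1.4-fold higher number from compound 3 to compound 4 (0.15 log units; that floor lies within the scatter), and since these are only floors within the scatter, none of them yet shows a real rise. The steps among compound 1, compound 2 and compound 3 still cannot be read, and most values stay at the limit: the limit of < 7 mL.min-1.g-1 in this assay, at which 3 of the 4 values shown sit.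

The new group differs from the old ones in its ring, its link and its end group at once, and the compounds shown cannot say which part matters. From the compounds shown here alone, what a carboxylic acid in place of the carbamoyl would give also stays open.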